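The source may hold more compounds than are shown below. What is called first, only, known or untested is meant among the compounds shown, and "the series" means these compounds.

Measured so far in an ADME assay on HEL cells (Homo sapiens) for cytotoxicity, with a stated time of 3 days; on this read-out lower numbers stand for higher toxicity in this test and higher numbers for lower toxicity in this test:
Compound 1 `Cc1cc(-c2ccco2)cn2c(CSCCc3ccccc3)cnc12` gives > 4 ug/mL, a limit of the assay and not a number.
Compound 2 `Cc1cc(N2CCCC2)cn2c(CSCCc3ccccc3)cnc12` gives 20 ug/mL.
Compound 3 `Cc1cc(-n2cccc2)cn2c(CSCc3ccccc3)cnc12` gives 20 ug/mL.

On these data alone, compound 1 thus stands only at a limit in this assay, namely (the limit of > 4 ug/mL in this assay, at which 1 of the 3 values shown sits), so its true value is unknown. The move to compound 4 `Cc1cc(-n2ccnc2)cn2c(CSCCc3ccccc3)cnc12` puts (1H-imidazol-1-yl in place of furan-2-yl on an aromatic carbon). Within the data shown here, the one measured step from the same start, a step that the limit leaves unreadable from compound 1 to compound 2, is likewise unreadable because of that limit. Compound 2 with pyrrolidin-1-yl gives 20 ug/mL, and compound 3 with pyrrol-1-yl gives 20 ug/mL; no direction beyond the scatter can be expected for compound 4. Compound 4 is therefore estimated at 20 ug/mL, between 8 ug/mL and 45 ug/mL. The expected step from compound 1 to compound 4 is a step that the limit leaves unreadable from compound 1 to compound 4.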

Compound 4, minimum cytotoxic concentration: 100 ug/mL
For compound 4 the middle estimate is 5.0-fold (0.70 log units) below the measured one; the whole stated range lies below it.
By their numbers in this assay, from the lowest: compounds 2 and 3 (each within the scatter of the next); then compound 4.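

In this assay, this aromatic carbon, meta to a methyl group, now gives a readable change: 1H-imidazol-1-yl in place of pyrrolidin-1-yl produces a 5.0-fold higher number from compound 2 to compound 4 (0.70 log units; beyond the scatter). Swapping this one group therefore moves the read-out beyond the scatter, towards lower toxicity in this test. Compound 1 stands only at a limit, so the steps from it cannot be read: the limit of > 4 ug/mL in this assay, at which 1 of the 4 values shown sits.

On these data alone, how a dimethylamino group or a carboxylic acid on this carbon would read stays open. So does whether this step would hold with the side chain of compound 3.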